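Swapping an Ether Chain for a Ring on the Ester

This account rests on a few compounds, and the source may have more. Where it says the series, first, only, none or still open, it means among the compounds named here.

Compound 1 `CC(C)OCCOC(=O)c1cccc(-c2cc(C(=O)Nc3ccncc3F)ccc2CN)c1` shares its core with compound 2 `CCCCCOC(=O)c1cccc(-c2cc(C(=O)Nc3ccncc3)ccc2CN)c1` and compound 3 `CCOC(=O)c1cccc(-c2cc(C(=O)Nc3ccncc3)ccc2CN)c1`; the three differ chiefly in the group attached to the ester oxygen, and compound 1 differs from the other two in more than one place. In an assay on isolated protein for inhibition of Rho-associated protein kinase 2 (Homo sapiens), read by radiometric assay (on this read-out higher numbers stand for weaker inhibition and lower numbers for stronger inhibition), compound 1 gives 37 nM, the highest of the two numbers recorded. Compound 2 gives 4.9 nM in this assay. Compound 3 reaches a limit of this assay, < 1 nM, which is a limit and not a number (the limit of < 1 nM in this assay, at which 1 of the 3 values shown sits). Within the data shown here, the only step between compounds differing in one place, an at least 4.9-fold lower number from compound 2 to compound 3 (0.69 log units; beyond the scatter), shows that shortening the ester chain strengthened inhibition.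

Compound 4 `NCc1ccc(C(=O)Nc2ccncc2F)cc1-c1cccc(C(=O)OC2CCCOC2)c1` has not yet been measured. It differs from compound 1 by oxan-3-yl in place of 2-isopropoxyethyl on an oxygen next to a carbonyl group. The measured step concerns chain length, whereas this change exchanges a chain for a ring of equal size, so it bears only loosely here. Compound 4 is therefore expected to give about 30 nM in this assay, between 8 nM and 110 nM. The expected step, a 1.2-fold lower number from compound 1 to compound 4 (0.09 log units; within the scatter), is estimated to stay within the scatter.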

Compound 4, half-maximal inhibitory concentration: 8.7 nM
The estimate for compound 4 lay 3.4-fold (0.54 log units) above the measured number; the range from low to high includes it.
By their numbers in this assay, from the lowest: compounds 2 and 4 (each within the scatter of the next); then compound 1. At a limit, below all of these: compound 3.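

In this assay, putting the oxan-3-yl ring in place of the open 2-isopropoxyethyl chain on the ester oxygen gives a 4.3-fold lower number from compound 1 to compound 4 (0.63 log units; beyond the scatter). The earlier step changed only the length of a chain, whereas here the two groups have the same counts of heavy atoms, carbon, oxygen and hydrogen-bond acceptors, and the number still moves when a ring replaces a chain. Nothing measured here accounts for the difference.

Going by these compounds, it remains open whether the ring oxygen itself matters, which a cyclohexyl ester would test, and whether a ring carrying an amine, such as piperidin-3-yl, would give a similar number. On these data alone, the effect of the oxan-3-yl ring on the core of compound 3, which has no fluorine, also remains open.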